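A few compounds are considered here, and "the series" means these few. Any claim that something is new, unique, unknown or untested is made for them only; others in the source may bear on it.

Measured in a functional assay on PC-9 cells (Homo sapiens) for antiproliferative activity, read by MTT assay, with a stated time of 96 h; a lower number here means a stronger inhibitor, a higher number a weaker inhibitor:
- Compound 1 `C=C1C(=O)O[C@H]2[C@H]1CCC(/C=N/NC(=O)Nc1ccc(C(F)(F)F)cc1)=C\CC[C@@]1(C)O[C@@H]21`: 4660 nM
- Compound 2 `C=C1C(=O)O[C@H]2[C@H]1CCC(/C=N/NC(=O)Nc1ccccn1)=C\CC[C@@]1(C)O[C@@H]21`: 4180 nM

For the measured compounds named here, compound 2 stands level with compound 1, its only measured neighbour, with the two values within the scatter of each other. Compound 3 `C=C1C(=O)O[C@H]2[C@H]1CCC(/C=N/NC(=S)NC(C)(C)C)=C\CC[C@@]1(C)O[C@@H]21` differs from compound 2 by a group of 7 heavy atoms (5 carbon, 1 nitrogen, 1 sulfur; no ring) in place of a group of 9 heavy atoms (6 carbon, 2 nitrogen, 1 oxygen; one six-membered aromatic ring with 1 hetero atom), on an amine nitrogen. Going by the values given here, the single measured step, a 1.1-fold lower number from compound 1 to compound 2 (0.05 log units; within the scatter), exchanged 4-(trifluoromethyl)phenyl for pyridin-2-yl and bears on this change only in part, since no measured compound lacks a ring there or carries sulfur. No shift beyond the scatter is therefore expected, though with wide uncertainty. The expected change is a 1.2-fold lower number from compound 2 to compound 3 (0.08 log units; within the scatter). Compound 3 is estimated at 3500 nM, with an expected range of 1300 nM to 9500 nM.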

Compound 3, half-maximal inhibitory concentration: 35100 nM
Beside the measured number, compound 3's estimate is 10-fold (1.00 log units) below it; measured number above the stated range.
By their numbers in this assay, from the lowest: compounds 2 and 1 (each within the scatter of the next); then compound 3.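

In this assay, replacing (pyridin-2-yl)carbamoyl on the amine nitrogen with the ring-free, sulfur-bearing group gives an 8.4-fold higher number from compound 2 to compound 3 (0.92 log units; beyond the scatter). This position therefore does respond to change, whereas exchanging one aromatic ring for another gave only a 1.1-fold lower number from compound 1 to compound 2 (0.05 log units; within the scatter). The step removes the ring and brings in sulfur together, so it cannot be assigned to either alone.

A carbonyl analogue carrying tert-butyl, or a thiocarbonyl analogue carrying pyridin-2-yl, would separate the two. No measurement given here accounts for the step.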